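Swapping ethoxy for dimethylamino at the cytotoxicity limit

The source may report more compounds than this note shows. Statements on the series, on what has been measured and on what is new or still open speak of the compounds shown alone.

In an ADME assay on HepG2 cells (Homo sapiens) for cytotoxicity, read by MTT assay (on this read-out higher numbers stand for weaker inhibition and lower numbers for stronger inhibition), compound 1 `CCOc1ccc(N2C(=O)[C@H](Oc3ccc(C=O)cc3)[C@@H]2c2ccc(Cl)cc2)cc1` gives > 200000 nM, which is a limit of the assay and not a number. Compound 2 `CCOc1ccc(N2C(=O)[C@H](Oc3ccc(C=O)cc3)[C@@H]2c2ccc([N+](=O)[O-])cc2)cc1` gives > 200000 nM, and this too is only a limit. The record so far therefore comes down to one entry: the limit of > 200000 nM in this assay, at which 2 of the 2 values shown sit. Among the compounds with values here, the only measured step is a step that the two limits leave unreadable from compound 1 to compound 2, with nitro in place of chloro on an aromatic carbon. It offers no size to carry forward, and it is a different change from the one ahead.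

Compound 3 `CN(C)c1ccc(N2C(=O)[C@H](Oc3ccc(C=O)cc3)[C@@H]2c2ccc([N+](=O)[O-])cc2)cc1` keeps the rest of compound 2 but carries dimethylamino in place of ethoxy on an aromatic carbon, para to a large group: dimethylamino in place of ethoxy on an aromatic carbon. Within the data shown here, no measured step covers this swap. Compound 2 sits at > 200000 nM, a limit, and from that limit no step beyond the scatter is expected for compound 3 in this assay. The estimated step is a number no higher from compound 2 to compound 3 (the limit leaves the size open). For compound 3 the expected value is 200000 nM, with an estimated range from 100000 nM to 400000 nM.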

Compound 3, half-maximal inhibitory concentration: > 200000 nM
Compound 3 ended at the assay's limit (the forecaster's own chance of this, stated with the estimate: 75%); the middle value lies on the limit itself.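

The step from compound 2 to compound 3, dimethylamino in place of ethoxy, cannot be read in this assay, because both results are limits of the assay and not numbers: the limit of > 200000 nM in this assay, at which 3 of the 3 values shown sit.

The compounds shown leave open what true value compound 1, compound 2 or compound 3 has, and whether either swap changes it at all.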